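The source may hold more compounds than are shown below. What is called first, only, known or untested is meant among the compounds shown, and "the series" means these compounds.

Three compounds share one core and differ only in the group on a single aromatic carbon. Compound 1 `CCCCCCCCCCc1ccc(-c2noc(CC3CCNC3)n2)cc1` gives 44% in an assay on HeLa cells for inhibition of sphingosine-1-phosphate transporter SPNS2 (Mus musculus), read by LC-MS, tested at 2 uM; on this read-out higher numbers stand for more inhibition at the one concentration tested (going by the name of the read-out) and lower numbers for less inhibition. Compound 2 `CCCCCCCCCCc1ccc(-c2noc([C@H]3CCCN3)n2)cc1` gives 12% in this assay, and compound 3 `CCCCCCCCCCc1ccc(-c2noc([C@@H]3CC[C@H](N)C3)n2)cc1` gives 38% in this assay. Compound 3 stands second of the three: its number lies within the scatter of compound 1, while the step of a number 26 percentage points higher from compound 2 to compound 3 (beyond the scatter) sets it apart from compound 2. Compound 4 `CCCCCCCCCCc1ccc(-c2noc(C(Cl)CCN)n2)cc1` has not yet been measured. From compound 3 to compound 4 the change is a group of 5 heavy atoms (3 carbon, 1 nitrogen, 1 chlorine; no ring) in place of a group of 6 heavy atoms (5 carbon, 1 nitrogen; one five-membered non-aromatic ring of carbon only), on an aromatic carbon. Among the measured compounds shown here, no measured step opens a ring in this way, so the comparisons are indirect: the step of a number 6 percentage points lower from compound 1 to compound 3 (within the scatter) stayed within the scatter when one ring-bearing amine replaced another, whereas the step of a number 32 percentage points lower from compound 1 to compound 2 (beyond the scatter) was large. The measured steps thus show that reshaping the amine-bearing group has moved the number either strongly or not at all, and a modest downward step is expected for compound 4. Compound 4 is expected to give 25% (from 5% to 45%), meaning an expected step of a number 13 percentage points lower from compound 3 to compound 4 (beyond the scatter).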

Compound 4, a percentage reported as inhibition, at one concentration (the size of the read-out at that concentration, not a potency): 5%
Estimate against measurement, compound 4: 20 percentage points above; measured number inside the range.
By their numbers in this assay, from the lowest: compounds 4 and 2 (each within the scatter of the next); then compounds 3 and 1 (each within the scatter of the next).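

The group with no ring, carrying a chlorine, gives up much of the number at this position: the drop is large both in a number 33 percentage points lower from compound 3 to compound 4 (beyond the scatter) and in a number 39 percentage points lower from compound 1 to compound 4 (beyond the scatter). A ring alone does not secure a high number here, however, since a number 7 percentage points lower from compound 2 to compound 4 (within the scatter) leaves the open-chain group level with the pyrrolidin-2-yl group, and compounds 2 and 4 both lie well under compounds 1 and 3. Nothing available here explains this loss. In compound 4 the ring is gone and a chlorine has arrived in one change, so the two cannot be told apart. Still open, going by these compounds, is whether the same open chain with a hydrogen, a fluorine or a hydroxyl group in place of the chlorine would give a number like that of compound 3 or compound 2.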